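The source may hold more compounds than are shown below. What is called first, only, known or untested is meant among the compounds shown, and "the series" means these compounds.

Measured compounds
- Compound 1 `O=C(/C=C/c1ccc(OCc2cn(Cc3cccc(Br)c3)nn2)cc1)c1ccc(Br)cc1`: 43% in a functional assay on MIA PaCa-2 cells (Homo sapiens) for inhibition, read by MTT assay, with a stated time of 48 h, tested at 10 uM; on this read-out lower numbers stand for less inhibition of growth and higher numbers for more inhibition of growth at the one concentration tested
- Compound 2 `O=C(/C=C/c1ccc(OCc2cn(Cc3cccc(Br)c3)nn2)cc1)c1ccc([N+](=O)[O-])cc1`: 21% in this assay

Among the compounds with values here, compound 2 stands lowest of the two numbers in this assay; its nearest neighbour is compound 1, and the one measured step, a number 22 percentage points lower from compound 1 to compound 2 (beyond the scatter), lies beyond the scatter.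

Compound 3 `O=C(/C=C/c1ccc(OCc2cn(Cc3ccc(F)cc3)nn2)cc1)c1ccc([N+](=O)[O-])cc1` is not yet measured. It differs from compound 2 by 4-fluorophenyl in place of 3-bromophenyl on a saturated chain carbon bound to an aromatic nitrogen. Within the data shown here, the only measured step concerns the bromo-to-nitro exchange on the aromatic carbon of the ketone side, a different place from the change toward compound 3, so no measured step bears directly on it. With nothing to go on beyond the value of compound 2, the expectation is a step of a number 1 percentage points higher from compound 2 to compound 3 (within the scatter), that is, no change beyond the scatter. Compound 3 is therefore estimated at 22%, with a range from 8% to 40%.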

Compound 3, percent growth inhibition at one concentration: 44%
Compound 3: middle estimate off by 22 percentage points, on the low side; the measured number lies above the stated range.
By their numbers in this assay, from the lowest: compound 2; then compounds 1 and 3 (each within the scatter of the next).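

The aryl group on a saturated chain carbon bound to an aromatic nitrogen is now shown to affect the read-out in this assay: 4-fluorophenyl in place of 3-bromophenyl gives a number 23 percentage points higher from compound 2 to compound 3 (beyond the scatter) with the rest of the molecule unchanged. The series therefore responds at this place as well as at the aromatic carbon where nitro replaces bromo, the change that gave a number 22 percentage points lower from compound 1 to compound 2 (beyond the scatter) in the opposite direction. No data at hand explain the step at this place.

The change alters both the halogen and where it sits, and the compounds shown do not separate the two; 3-fluorophenyl and 4-bromophenyl at this place would. Also open, on these data alone, are whether the step holds with bromo in place of nitro on the aromatic carbon, and how an amine on this aryl group would read.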